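A few compounds are considered here, and "the series" means these few. Any claim that something is new, unique, unknown or untested is made for them only; others in the source may bear on it.

Measured so far:
- compound 1 `O=C(Nc1ccc(Cl)c(-c2nnc3c(Cl)cccn23)c1)c1cccnc1`; in a functional assay on A549 cells (Homo sapiens) for antiproliferative activity, read by MTT assay, with a stated time of 72 h (on this read-out higher numbers stand for weaker inhibition and lower numbers for stronger inhibition), compound 1 gives > 100000 nM, which is a limit of the assay (the limit of > 100000 nM in this assay, at which 1 of the 3 values shown sits).
- compound 2 `O=C(Nc1ccc(Cl)c(-c2nnc3c(Cl)cccn23)c1)c1ccc(Cl)cc1`; in this assay compound 2 gives 73600 nM.
- compound 3 `O=C(Nc1ccc(Cl)c(-c2nnc3c(Cl)cccn23)c1)c1ccccc1`; in this assay compound 3 gives 76900 nM.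

Compound 3 stands highest of the two numbers, but its nearest neighbour compound 2 sits within the scatter: a 1.0-fold higher number from compound 2 to compound 3 (0.02 log units; within the scatter). The two steps from compound 1, an at least 1.3-fold lower number from compound 1 to compound 2 (0.13 log units; that floor lies within the scatter) and an at least 1.3-fold lower number from compound 1 to compound 3 (0.11 log units; that floor lies within the scatter), are bounded by the limit and their floors also lie within the scatter, so none of the three measured steps shows a real change in this assay.

Compound 4 `CS(=O)(=O)c1cccc(C(=O)Nc2ccc(Cl)c(-c3nnc4c(Cl)cccn34)c2)c1` differs from compound 3 in one place: methylsulfonyl in place of hydrogen on an aromatic carbon. For the measured compounds named here, the only measured step that touches this ring, a 1.0-fold higher number from compound 2 to compound 3 (0.02 log units; within the scatter), exchanged chloro for hydrogen and stayed within the scatter. Going by the values given here, no measured step involves methylsulfonyl or any other substituent of this kind, so the expectation rests on the flatness of the series alone. The step from compound 3 to compound 4 is therefore expected to be a 1.0-fold lower number from compound 3 to compound 4 (0.01 log units; within the scatter), that is, no change beyond the scatter, with a real chance that only a limit is returned.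

Compound 4 is estimated at 75000 nM in this assay, with a range from 25000 nM to 150000 nM.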

Compound 4, half-maximal inhibitory concentration: > 100000 nM
Compound 4 was reported as a limit; the forecaster's own chance of this, stated with the estimate: 35%; middle value at least 1.3-fold (0.12 log units) away from the limit.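

In this assay compound 4 gives > 100000 nM, which is a limit of the assay, so methylsulfonyl on this carbon, meta to a large group, yields no number that can be set exactly against the other compounds. The readable steps are only floors, an at least 1.3-fold higher number from compound 3 to compound 4 (0.11 log units; that floor lies within the scatter) and an at least 1.3-fold higher number from compound 2 to compound 4 (0.13 log units; that floor lies within the scatter), so neither shows a real change from placing this group on the phenyl ring. What is new is that a compound with a substituted phenyl group, and not only the pyridin-3-yl compound 1, now sits at this limit: the limit of > 100000 nM in this assay, at which 2 of the 4 values shown sit.

The step from compound 1 to compound 4 cannot be read, and neither limit tells how much weaker either compound may be than compounds 2 and 3. Going by these compounds, it remains open whether an amine, a carboxylic acid or a methoxy group on the same carbon would give a number beyond the scatter from compound 3, and whether methylsulfonyl at the place held by chloro in compound 2 would give a measurable value.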